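The source may report more compounds than this note shows. Statements on the series, on what has been measured and on what is new or still open speak of the compounds shown alone.

Series notes, step from compound 2 to compound 4.

Compound 2 `CCN(CC)c1ccc2cc(C(=O)c3ccc(N4CCN(C(=O)CN5CCN(S(=O)(=O)c6ccc(C#N)cc6)CC5)CC4)cc3)oc2c1` is one of three analogues sharing the same core and differing only in the group on the amine nitrogen in a ring at the far end. In a functional assay on A549 cells (Homo sapiens) for cytotoxicity, read by MTT assay, with a stated time of 48 h (on this read-out lower numbers stand for stronger inhibition and higher numbers for weaker inhibition), compound 2 gives only a limit, > 40000 nM. Compound 1 `CCN(CC)c1ccc2cc(C(=O)c3ccc(N4CCN(C(=O)CN5CCN(S(=O)(=O)c6ccc(OC(F)(F)F)cc6)CC5)CC4)cc3)oc2c1` likewise gives only a limit in this assay, > 40000 nM. Together these two form (the limit of > 40000 nM in this assay, at which 2 of the 3 values shown sit). Among the compounds with values here, compound 3 `CCN(CC)c1ccc2cc(C(=O)c3ccc(N4CCN(C(=O)CN5CCN(Cc6ccc(C#N)cc6)CC5)CC4)cc3)oc2c1` is the single analogue with a number in this assay, giving 17400 nM.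

Of the two measured steps, a step that the two limits leave unreadable from compound 1 to compound 2 cannot be sized, since both values are limits. The other, an at least 2.2-fold lower number from compound 2 to compound 3 (0.36 log units; beyond the scatter), is the one that bears on the present change: it also removes the (4-cyanophenyl)sulfonyl from the ring nitrogen, and the number came down.

Compound 4 `CCOC(=O)CN1CCN(CC(=O)N2CCN(c3ccc(C(=O)c4cc5ccc(N(CC)CC)cc5o4)cc3)CC2)CC1` is not yet measured. It differs from compound 2 by (ethoxycarbonyl)methyl in place of (4-cyanophenyl)sulfonyl on an amine nitrogen in a ring. Unlike compound 3, the entering group has no ring, so whether a number or again only a limit results is open; a modest move downward, as seen with compound 3, is the nearest guide. For compound 4 the expected step is an at least 1.3-fold lower number from compound 2 to compound 4 (0.12 log units; that floor lies within the scatter). Compound 4 is estimated at 30000 nM in this assay, within 10000 nM to 100000 nM.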

Compound 4, half-maximal inhibitory concentration: > 40000 nM
Compound 4 gave a limit, no number; the forecaster's own chance of this, stated with the estimate: 50%; at least 1.3-fold (0.12 log units) between middle value and limit.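

In this assay compound 4 gives > 40000 nM, which is a limit and not a number. The steps that join two limits cannot be read, but the comparison with compound 3 can: with ethoxycarbonyl in place of 4-cyanophenyl on the saturated chain carbon bound to the amine nitrogen in a ring, the data show an at least 2.2-fold higher number from compound 3 to compound 4 (0.36 log units; beyond the scatter), so removing the (4-cyanophenyl)sulfonyl is not enough by itself to bring a number into range at this position. Of the four analogues, only compound 3, with its 4-cyanobenzyl, gives a number, while compound 1, compound 2 and compound 4 share the same limit: the limit of > 40000 nM in this assay, at which 3 of the 4 values shown sit.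

The compounds shown do not separate the contribution of the aromatic ring in the 4-cyanobenzyl from that of its nitrile, a question that an unsubstituted benzyl or a 4-methoxybenzyl on the same ring nitrogen would address. Nor do they show how a carboxylic acid in place of the ethyl ester, or a longer chain carrying the ester, would read, and any order among compound 1, compound 2 and compound 4 remains unknown.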